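The source may hold more compounds than are shown below. What is called first, only, known or untested is meant among the compounds shown, and "the series" means these compounds.

In a functional assay on Coronary artery (Bos taurus); a higher number here means that more compound is needed for the effect, a lower number that less compound is needed:

- compound 1 `CCCCCCC(=O)N(CCCC/C=C\CCCCCCC(=O)OCCOCCOCCO)C(C)C`: 2900 nM
- compound 2 `CCCCNC(=O)C(=O)NCCCC/C=C\CCCCCCC(=O)OCCOCCOCCO`: 1500 nM
- compound 3 `CCCCCCC(=O)N(CCCC/C=C\CCCCCCc1nnn[nH]1)C(C)C`: not yet measured

For the measured compounds named here, compound 1 cannot be separated from compound 2, the only other measured compound. Going by the values given here, the single measured step is a 1.9-fold lower number from compound 1 to compound 2 (0.29 log units; within the scatter). Moving to compound 3 brings (a group of 5 heavy atoms (1 carbon, 4 nitrogen; one five-membered aromatic ring with 4 hetero atoms) in place of a group of 12 heavy atoms (7 carbon, 5 oxygen; no ring), on a saturated chain carbon, six bonds along the chain from a double-bonded chain carbon). The measured step altered a different place, so it bears only indirectly, and no measurement covers this replacement. No shift beyond the scatter can therefore be derived, and only a small step is expected in this assay. The expected step is a 1.9-fold lower number from compound 1 to compound 3 (0.29 log units; within the scatter). Compound 3 is estimated at 1500 nM, with an expected range of 200 nM to 6000 nM.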

Compound 3, half-maximal effective concentration: 1000 nM
Compound 3: middle estimate off by 1.5-fold (0.18 log units), on the high side, within the range that was stated.
By their numbers in this assay, from the lowest: compounds 3, 2 and 1 (each within the scatter of the next, the first and the last beyond it).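

In this assay, for the compounds shown here, the first change at this position, on a saturated chain carbon, six bonds along the chain from a double-bonded chain carbon, gives a 2.9-fold lower number from compound 1 to compound 3 (0.46 log units; beyond the scatter). The ringless group of 12 heavy atoms can therefore give way to the smaller 1H-tetrazol-5-yl with less compound needed for the effect, a modest step beyond the scatter. No available evidence accounts for this shift. The compounds shown leave open whether the 1H-tetrazol-5-yl ring itself matters or whether removing the longer chain is enough, a question that a carboxylic acid at this place could address.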